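The compounds below may be only part of what the source reports. "The series", "measured", "known", "first", "only" and "open" are said of these compounds alone.

Compound 1 `COc1cccc([C@@H](CO)O[C@H]2CCCN(Cc3ccc(C(=O)O)cc3C)[C@H]2c2ccccc2)c1` carries a methoxyphenyl group and a hydroxymethyl group on the oxygen attached to its saturated ring. In an assay on isolated protein for activation of cGMP-dependent protein kinase 1 (Homo sapiens), read by ADP-Glo, with stated times of 30 min and 2 h (a lower number here means that less compound is needed, a higher number that more compound is needed for the effect), compound 1 gives only a limit of the assay, > 200000 nM, rather than a number. That limit, (the limit of > 200000 nM in this assay, at which 1 of the 3 values shown sits), marks where compound 1 stands among the results gathered so far. Two related compounds have been examined in this assay. Compound 2 `Cc1cc(C(=O)O)ccc1CN1CCC[C@H](O[C@H](CO)c2cc(Cl)cc(Cl)c2)[C@@H]1c1cccc(F)c1` has "nd" (no result reported), so nothing can be drawn from it. Compound 3 `Cc1cc(C(=O)O)ccc1CN1CC[C@H](OC(CO)c2cc(Cl)cc(Cl)c2)[C@@H]1c1ccccc1`, which has a smaller saturated ring and a dichlorophenyl group beside the hydroxymethyl group, gives 185000 nM.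

Compound 4 `Cc1cc(C(=O)O)ccc1CN1CCC[C@H](O[C@H](CF)c2cc(Cl)cc(Cl)c2)[C@@H]1c1ccccc1` is the compound still to be tested. It differs from compound 1 in one place: a group of 11 heavy atoms (8 carbon, 1 fluorine, 2 chlorine; one six-membered aromatic ring of carbon only) in place of a group of 11 heavy atoms (9 carbon, 2 oxygen; one six-membered aromatic ring of carbon only), on an oxygen on a saturated carbon. In plain terms the methoxyphenyl becomes a dichlorophenyl and the hydroxymethyl becomes a fluoromethyl, while the rest of the shared core is unchanged.

Going by the values given here, no measured pair shows this change by itself, so the size of the step is uncertain. Compound 1 itself sits only at a limit of the assay. Given that compound 3 with a dichlorophenyl group gives 185000 nM, the step from compound 1 to compound 4 in this assay is expected to be an at least 1.6-fold lower number from compound 1 to compound 4 (0.22 log units; that floor lies within the scatter), at most modest and not clearly beyond the scatter. Compound 4 is therefore expected to give about 120000 nM, with a range from 20000 nM to 300000 nM, and a fair chance that only a limit is reported.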

Compound 4, half-maximal effective concentration: 20000 nM
Estimate against measurement, compound 4: 6.0-fold (0.78 log units) above, and the stated range covers the measured number.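

Going by these compounds alone, the change on an oxygen on a saturated carbon, with methoxyphenyl becoming dichlorophenyl and hydroxymethyl becoming fluoromethyl, gives the first readable step in this set: an at least 10-fold lower number from compound 1 to compound 4 (1.00 log units; beyond the scatter) in this assay. This shows that the group at this place can move the result beyond the usual scatter while the rest of the shared core stays the same, and here compound 4 gives a plain number, 20000 nM. The true size of the step stays unknown, and the printed figure is only a floor, because compound 1 gives a limit of the assay and not a number: the limit of > 200000 nM in this assay, at which 1 of the 4 values shown sits.

The compounds shown do not separate the two parts of the change, so it stays open whether the dichlorophenyl, the fluoromethyl or only the two together carry the step, even though the group that enters has 0 hydrogen-bond donors where the group that leaves has 1. They also leave open how this assay would read with a difluoromethyl, a methoxymethyl or an aminomethyl group in place of the fluoromethyl.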